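The compounds below may be only part of what the source reports. "The series", "measured", "known", "first", "only" and "open" are said of these compounds alone.

In an ADME assay on MDCK cells (Canis lupus familiaris) for cytotoxicity, read by microscopy, with a stated time of 6 days (on this read-out higher numbers stand for lower toxicity in this test and lower numbers for higher toxicity in this test), compound 1 `CCCN1C(N)=NC(N)=NC12CCN(C(=O)NCCC(=O)OCC)CC2` gives > 100000 nM, which is a limit of the assay rather than a number. Compound 2 `CCCN1C(N)=NC(N)=NC12CCN(S(=O)(=O)CCC)CC2` likewise gives > 100000 nM, again a limit. Going by the values given here, compound 3 `COCCN1C(N)=NC(N)=NC12CCN(C(=O)C1CC1)CC2` gives > 100000 nM, also a limit, so compound 3 stands where every value so far stands, at the limit of > 100000 nM in this assay, at which 3 of the 3 values shown sit. Compound 4 `COCCN1C(N)=NC(N)=NC12CCN(C(=O)NC1CCC(C)CC1)CC2` has yet to be tested in this assay; it differs from compound 3 as follows ((4-methylcyclohexyl)amino in place of cyclopropyl on a carbonyl carbon). Among the compounds with values here, no measured step between two compounds exists here, and no step beyond the usual scatter is expected, since compound 3 already sits at the limit of > 100000 nM in this assay, at which 3 of the 3 values shown sit. Compound 4 is therefore expected to give 100000 nM, within a range of 50000 nM to 200000 nM. The expected step is a number no higher from compound 3 to compound 4 (the limit leaves the size open), essentially none beyond the scatter.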

Compound 4, minimum cytotoxic concentration: > 100000 nM
Compound 4 gave a limit, no number; the forecaster's own chance of this, stated with the estimate: 85%; the middle value sits exactly at the limit.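

In this assay no step can be read from compound 3 to compound 4, as both values are limits of the assay: the limit of > 100000 nM in this assay, at which 4 of the 4 values shown sit. The compounds shown leave open which structural change, if any, would yield a measurable cytotoxic concentration.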